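A few compounds are considered here, and "the series" means these few. Any claim that something is new, unique, unknown or untested is made for them only; others in the source may bear on it.

Compound 1, `CC(C)c1ccccc1-c1nc(NCc2ccc(-c3cccnc3)cc2)c2ccccc2n1`: 180 nM in an assay on a protein complex for inhibition of ubiquitin carboxyl-terminal hydrolase 1/WD repeat-containing protein 48 (Homo sapiens), read by fluorescence; on this read-out higher numbers stand for weaker inhibition and lower numbers for stronger inhibition
Compound 2, `Clc1ccccc1-c1nc(NCc2ccc(-c3cccnc3)cc2)c2ccccc2n1`: 2100 nM in this assay
Compound 3, `Brc1ccccc1-c1nc(NCc2ccc(-c3cccnc3)cc2)c2ccccc2n1`: 1600 nM in this assay

Compound 3 stands second highest of the three numbers in this assay. Its nearest neighbour is compound 2, with a 1.3-fold lower number from compound 2 to compound 3 (0.12 log units; within the scatter), a gap within the scatter; its furthest is compound 1, with an 8.9-fold higher number from compound 1 to compound 3 (0.95 log units; beyond the scatter). The step to compound 4, `c1cncc(-c2ccc(CNc3nc(-n4ccnc4)nc4ccccc34)cc2)c1`, is 1H-imidazol-1-yl in place of 2-bromophenyl on an aromatic carbon. Among the compounds with values here, no measured step bears directly on this change: the three steps seen, a 12-fold higher number from compound 1 to compound 2 (1.07 log units; beyond the scatter), an 8.9-fold higher number from compound 1 to compound 3 (0.95 log units; beyond the scatter) and a 1.3-fold lower number from compound 2 to compound 3 (0.12 log units; within the scatter), all swap one group on the 2-bromophenyl ring and leave that ring in place, whereas here the whole ring is exchanged. Those steps do show that this position can move the number a great deal. Within the data shown here, with no direct precedent, compound 4 is expected to land somewhat weaker than compound 3, with a wide uncertainty, an estimated step of a 3.1-fold higher number from compound 3 to compound 4 (0.49 log units; beyond the scatter). The estimate for compound 4 in this assay is therefore 5000 nM, with a range from 800 nM to 30000 nM.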

Compound 4, half-maximal inhibitory concentration: "not active" (no number reported)
Compound 4: no number reported, and the estimate cannot be compared.
By their numbers in this assay, from the lowest: compound 1; then compounds 3 and 2 (each within the scatter of the next).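

Within the data shown here, compound 4 was reported as "not active" in this assay without a number, so no step from compound 3 or any other compound to compound 4 can be read. As far as these compounds go, how far 1H-imidazol-1-yl in place of 2-bromophenyl moves the number stays open, and no supporting data bear on this result.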